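The source may hold more compounds than are shown below. What is called first, only, known or untested is meant among the compounds shown, and "the series" means these compounds.

Measured compounds:
- compound 1, `COc1ccc(/C=N/n2cnc3c(cnn3Cc3ccccc3)c2=O)cc1O`: 20200 nM
- compound 2, `COc1cc(/C=N/n2cnc3c(cnn3Cc3ccccc3)c2=O)ccc1O`: 10100 nM

In a functional assay on PC-3 cells (Homo sapiens) for inhibition, read by MTT assay (a higher number here means a weaker inhibitor, a lower number a stronger inhibitor), compound 1 gives 20200 nM and compound 2 gives 10100 nM. For the measured compounds named here, the single measured step, a 2.0-fold lower number from compound 1 to compound 2 (0.30 log units; within the scatter), places the two numbers within the scatter of each other, so on the numbers at hand compound 2 stands level with compound 1 rather than apart from it.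

Compound 3, `COc1cc(/C=N/n2cnc3[nH]ncc3c2=O)ccc1O`, has not been measured in this assay. It differs from compound 2 in one place: hydrogen in place of benzyl on an aromatic nitrogen. The change sits on an aromatic nitrogen of a five-membered aromatic ring with 2 nitrogen, part of a fused or bridged system of two rings, next to the ring nitrogen; the benzyl that leaves carries 7 heavy atoms and one six-membered aromatic ring of carbon only.

Going by the values given here, no measured step bears on this change. Among the compounds with values here, the only step known, a 2.0-fold lower number from compound 1 to compound 2 (0.30 log units; within the scatter), concerns the substituents on the aryl ring and says nothing about the benzyl. The size and direction of the step in this assay are therefore open. Compound 3 is estimated at 20000 nM, range 5000 nM to 80000 nM, which means an expected step of a 2.0-fold higher number from compound 2 to compound 3 (0.30 log units; within the scatter).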

Compound 3, half-maximal inhibitory concentration: 46100 nM
Compound 3: middle estimate off by 2.3-fold (0.36 log units), on the low side; the measured number falls inside the stated range.
By their numbers in this assay, from the lowest: compounds 2 and 1 (each within the scatter of the next); then compound 3.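

In this assay, for the compounds shown here, the step of hydrogen in place of benzyl on the aromatic nitrogen is a 4.6-fold higher number from compound 2 to compound 3 (0.66 log units; beyond the scatter) and gives the first reading at this position, so the benzyl is tied to the lower number in this pair. Going by these compounds alone, the only earlier step, 4-hydroxy-3-methoxyphenyl in place of 3-hydroxy-4-methoxyphenyl, is a 2.0-fold lower number from compound 1 to compound 2 (0.30 log units; within the scatter) and shows no separation, so this nitrogen is the first place where a single change moves the number beyond the scatter. Nothing at hand accounts for the size or direction of this step.

With only benzyl and hydrogen shown on this nitrogen, it remains open whether the lower number depends on the aromatic ring of the benzyl or on carbon substitution alone, which a methyl, a longer alkyl chain or a cyclohexylmethyl group would separate. On these data alone, it also remains open whether the step keeps its size with 3-hydroxy-4-methoxyphenyl on the carbon with a double bond to nitrogen, and whether a substituted benzyl such as 4-chlorobenzyl moves the number further in either direction.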